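Shortening the side chain of compound 2

The source may report more compounds than this note shows. Statements on the series, on what has been measured and on what is new or still open speak of the compounds shown alone.

In an ADME assay on MDCK cells (Canis lupus familiaris) for cytotoxicity, read by crystal violet staining, with a stated time of 48 h (on this read-out higher numbers stand for lower toxicity in this test and lower numbers for higher toxicity in this test), compound 1 (`COc1c(CCCC(C)C)coc(=O)c1C`) gives 2000000 nM and compound 2 (`Cc1c(O)c(CCCCC(C)C)coc1=O`) gives 1290000 nM as its reading. These two values lie within the usual scatter of each other, so compound 2 cannot be separated from compound 1 on the numbers available.

Compound 3 (`Cc1c(O)c(CCCC(C)C)coc1=O`) has not yet been measured. The change from compound 2 to compound 3 is isopropyl in place of isobutyl on a saturated chain carbon, three bonds along the chain from an aromatic carbon and it amounts to isopropyl in place of isobutyl on a saturated chain carbon, three bonds along the chain from an aromatic carbon. Cut one bond further out, the same difference reads isopentyl to isobutyl.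

Among the measured compounds shown here, no measured pair shows this change on its own, so the data give no direct guide to its size. The only reference points are the two close readings already in hand, and no step beyond the scatter is expected in either direction. In this assay the expected step is a 1.2-fold higher number from compound 2 to compound 3 (0.07 log units; within the scatter) which would stay within the scatter. Compound 3 is estimated to read 1500000 nM (expected range 700000 nM to 3000000 nM).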

Compound 3, half-maximal cytotoxic concentration: 1240000 nM
Beside the measured number, compound 3's estimate is 1.2-fold (0.08 log units) above it, within the range that was stated.
By their numbers in this assay, from the lowest: compounds 3, 2 and 1 (each within the scatter of the next).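

In this assay the change of isobutyl to isopropyl on a saturated chain carbon, three bonds along the chain from an aromatic carbon, can now be read on its own, and it gives a 1.0-fold lower number from compound 2 to compound 3 (0.02 log units; within the scatter) with the rest of the structure held constant. At this position, then, the two chain ends cannot be told apart in this test. Compound 3 also isolates a second change, hydrogen in place of methyl on an oxygen on an aromatic ring, which gives a 1.6-fold lower number from compound 1 to compound 3 (0.21 log units; within the scatter) and likewise stays within the scatter, so neither single change separates the compounds here. No supporting data are available to explain these readings.

The compounds shown leave open whether a longer chain at the same place, or a chain ending in an amine or a carboxylic acid, would give a step beyond the scatter. They also leave open whether a larger group than methyl on the oxygen, such as ethyl or benzyl, would move the reading in this test.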